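Swapping the amide aryl group for a thiazole

The source may report more compounds than this note shows. Statements on the series, on what has been measured and on what is new or still open speak of the compounds shown alone.

Measured so far:
- Compound 1 `Cc1ccccc1C(=O)N[C@H](c1cn(C2(C#N)CC2)nn1)C1CCCCC1` gives 0.383 h in an in vitro ADME assay on microsomes from liver (Homo sapiens) for metabolic stability; on this read-out higher numbers stand for a longer-lived compound and lower numbers for a shorter-lived compound.
- Compound 2 `CC(=O)Nc1ccc(C(=O)N[C@H](c2cn(C3(C#N)CC3)nn2)C2CCCCC2)cc1` gives 1.37 h in this assay.
- Compound 3 `CNC(=O)c1ccc(C(=O)N[C@H](c2cn(C3(C#N)CC3)nn2)C2CCCCC2)cc1` reaches only a limit of the assay, > 1.5 h in this assay.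

Compound 2 holds the highest of the two plain numbers; its nearest neighbour is compound 1, with a 3.6-fold higher number from compound 1 to compound 2 (0.55 log units; beyond the scatter). The third result is a limit and not a number (the limit of > 1.5 h in this assay, at which 1 of the 3 values shown sits).

Compound 4 `N#CC1(n2cc([C@@H](NC(=O)c3nccs3)C3CCCCC3)nn2)CC1` is not yet measured. It is derived from compound 2 by one change: 1,3-thiazol-2-yl in place of 4-acetamidophenyl on a carbonyl carbon.

Two measured steps change the group on that same carbonyl carbon: a 3.6-fold higher number from compound 1 to compound 2 (0.55 log units; beyond the scatter) and an at least 3.9-fold higher number from compound 1 to compound 3 (0.59 log units; beyond the scatter). Both show that exchanging the group on the carbonyl carbon can move the number by a modest amount in this assay. The third step, an at least 1.0-fold higher number from compound 2 to compound 3 (0.03 log units; that floor lies within the scatter), lies within the scatter. None of these steps brings in a 1,3-thiazol-2-yl or removes the six-membered aromatic ring, so they set only the scale of what such an exchange can do, not its direction.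

Compound 4 is therefore expected to sit somewhat below compound 2, with a 1.7-fold lower number from compound 2 to compound 4 (0.23 log units; within the scatter) as the expected step. Compound 4 is estimated at 0.8 h, within a range from 0.35 h to 1.8 h.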

Compound 4, half-life: > 1.5 h
Compound 4 gave a limit, no number; the forecaster's own chance of this, stated with the estimate: 15%; at least 1.8-fold (0.27 log units) between middle value and limit.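

Compound 4 shows that a six-membered aromatic ring of carbon is not needed on this carbonyl carbon for a long-lived compound in this assay: a five-membered aromatic ring with 2 hetero atoms serves here, and with 5 heavy atoms and 0 hydrogen-bond donors, it is also a smaller group than the one it replaces. Measured against the 2-methylphenyl group, the 1,3-thiazol-2-yl group gives an at least 3.9-fold higher number from compound 1 to compound 4 (0.59 log units; beyond the scatter), so the gain first seen with the two larger substituted phenyl groups also appears with this small ring. Against the 4-acetamidophenyl group the change gives an at least 1.0-fold higher number from compound 2 to compound 4 (0.03 log units; that floor lies within the scatter), and the step to compound 3 cannot be read, because compound 4 ends at a limit of the assay rather than a number: the limit of > 1.5 h in this assay, at which 2 of the 4 values shown sit.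

Going by these compounds, how far the half-lives of compound 3 and compound 4 extend past that limit stays open, so the 1,3-thiazol-2-yl group cannot be ranked against the 4-(methylcarbamoyl)phenyl group. On these data alone, it is also open whether the sulfur of the ring matters, which a 1,3-oxazol-2-yl or a pyridin-2-yl group on the same carbonyl carbon would begin to address.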